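The compounds below may be only part of what the source reports. "The series", "measured", "known", "first", "only" and "open" are said of these compounds alone.

Measured compounds:
- compound 1, `COc1cc(C)cc(-c2c(-c3ccnc(-c4ccc(C(C)=O)cc4)c3)cnn2CC#N)c1`: 102%
- compound 2, `Cc1cc(O)cc(-c2nn(CC#N)cc2-c2ccnc(-c3ccc(Oc4ccccc4)cc3)c2)c1`: 101%
- compound 3, `COc1cc(C)cc(-c2nn(CC#N)cc2-c2ccnc(-c3ccc(N(C)C)cc3)c2)c1`: 102%

All three were tested in a functional assay on SNB-19 cells (Homo sapiens) for cytotoxicity, read by sulforhodamine B assay, with a stated time of 48 h, tested at 0.001 uM; a lower number here means a stronger effect, a higher number a weaker effect of the compound at the concentration tested. In this assay compound 1 gives 102%, compound 2 gives 101% and compound 3 gives 102%. Compound 3 stands level with compound 1 at the digits shown, and the two together are the highest of the three numbers; compound 2 lies within the usual scatter of repeated measurements of the other two. At the concentration used, then, none of the three shows any appreciable effect on cell growth, and no ordering among them can be read from these numbers.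

Compound 4, `Cc1cc(O)cc(-c2nn(CC#N)cc2-c2ccnc(-c3ccc(N(C)C)cc3)c2)c1`, has not been measured yet. It differs from compound 3 in one place: hydrogen in place of methyl on an oxygen on an aromatic ring.

Among the compounds with values here, with all three measured compounds sitting at essentially full activity, there is no step in the data from which a change of size could be read. The single alteration is small, and the expectation is that compound 4 behaves like compound 3, with a step from compound 3 to compound 4 of a number 1 percentage points lower from compound 3 to compound 4 (within the scatter), that is none beyond the scatter. Compound 4 is therefore expected to give about 101%, within a range from 90% to 112%.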

Compound 4, a percentage reported as activity, at one concentration (the size of the read-out at that concentration, not a potency): 96%
Beside the measured number, compound 4's estimate is 5 percentage points above it; low and high end bracket the measured number.
By their numbers in this assay, from the lowest: compounds 4, 2, 1 and 3 (each within the scatter of the next).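

In this assay, within the data shown here, replacing methoxy with hydroxy on the aromatic ring gives a number 6 percentage points lower from compound 3 to compound 4 (within the scatter), the first direct comparison at this position, and this step stays within the scatter, so at this concentration the methyl on that oxygen makes no measurable difference. With the hydroxy group held fixed, dimethylamino in place of phenoxy on an aromatic carbon gives a number 5 percentage points lower from compound 2 to compound 4 (within the scatter), also within the scatter, so neither single change separates the compounds in this read-out. No supporting measurement is available that could explain either step.

Among these compounds, all these results come from a single very low concentration at which no compound shows an appreciable effect on cell growth, so it remains open whether methoxy and hydroxy would still match at a concentration where growth is clearly affected. As far as these compounds go, it also remains open how a longer chain on the same oxygen, such as ethoxy, or an amine in place of the hydroxy group would read in this assay.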